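The source may report more compounds than this note shows. Statements on the series, on what has been measured and on what is new or still open speak of the compounds shown alone.

Three amides on the shared core of compound 1 `CCC(=O)N1CCc2nc(C#Cc3ccccc3)sc2C1` have been read in an assay on HEK293 cells for positive allosteric modulation of metabotropic glutamate receptor 5 (Homo sapiens), read by FLIPR, with a stated time of 1 h; on this read-out higher numbers stand for an effect only at larger amounts of compound and lower numbers for an effect already at smaller amounts. Compound 1 gives no number but only > 10000 nM, which is the limit of > 10000 nM in this assay, at which 1 of the 3 values shown sits. Compound 2 `COC1CC(C(=O)N2CCc3nc(C#Cc4ccccc4)sc3C2)C1` gives 640 nM, and compound 3 `O=C(C1CCCO1)N1CCc2nc(C#Cc3ccccc3)sc2C1` gives 790 nM. Both enlargements of the group on the carbonyl carbon give large steps: an at least 15-fold lower number from compound 1 to compound 2 (1.19 log units; beyond the scatter) and an at least 12-fold lower number from compound 1 to compound 3 (1.10 log units; beyond the scatter); the two larger groups themselves sit together, a 1.2-fold higher number from compound 2 to compound 3 (0.09 log units; within the scatter). Compound 3 thus holds the higher of the two measured numbers, with compound 2 within the scatter of it.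

The next step leads to compound 4 `N#Cc1cccc(C(=O)N2CCc3nc(C#Cc4ccccc4)sc3C2)c1`. 3-cyanophenyl in place of oxolan-2-yl on a carbonyl carbon The change again enlarges the group on the carbonyl carbon. For the measured compounds named here, the steps that bear on it are the two from the ethyl amide, an at least 15-fold lower number from compound 1 to compound 2 (1.19 log units; beyond the scatter) and an at least 12-fold lower number from compound 1 to compound 3 (1.10 log units; beyond the scatter), both large and toward lower numbers; the step of a 1.2-fold higher number from compound 2 to compound 3 (0.09 log units; within the scatter) between the two larger groups shows no further gain from exchanging one ring for another. A modest step toward a lower number in this assay, or none beyond the scatter, is therefore expected: a 2.0-fold lower number from compound 3 to compound 4 (0.30 log units; within the scatter). Compound 4 is estimated at 400 nM, with a range from 100 nM to 2500 nM.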

Compound 4, half-maximal effective concentration: 71 nM
The estimate for compound 4 lay 5.6-fold (0.75 log units) above the measured number; the whole stated range lies above it.
By their numbers in this assay, from the lowest: compound 4; then compounds 2 and 3 (each within the scatter of the next). At a limit, above all of these: compound 1.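

In this assay the group on the carbonyl carbon, whose other neighbour is an amide-type nitrogen in a ring, now separates larger groups from one another, which compound 2 and compound 3 had not shown: 3-cyanophenyl in place of oxolan-2-yl gives a large step (an 11-fold lower number from compound 3 to compound 4 (1.05 log units; beyond the scatter)), and 3-cyanophenyl in place of 3-methoxycyclobutyl gives a modest one (a 9.0-fold lower number from compound 2 to compound 4 (0.95 log units; beyond the scatter)). Groups larger than ethyl are therefore not interchangeable here, and among the compounds shown the one with an aromatic ring and a nitrile stands apart from the two with non-aromatic rings. Measured from the ethyl amide, the span reaches (an at least 140-fold lower number from compound 1 to compound 4 (2.14 log units; beyond the scatter)), but this step is only a bound, as compound 1 gives a limit and not a number: (the limit of > 10000 nM in this assay, at which 1 of the 4 values shown sits).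

From the compounds shown here alone, with a single aromatic example, it remains open whether the step belongs to the phenyl ring or to the nitrile, which plain phenyl would separate, and whether 3-methoxyphenyl or 3-chlorophenyl would read alike. Also open, going by these compounds, is how an amine or a carboxylic acid on that ring would read.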